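Hydroxyphenyl pyridines: thiophene to furan swap at second position

The source may report more compounds than this note shows. Statements on the series, on what has been measured and on what is new or still open speak of the compounds shown alone.

Compound 1 `Oc1ccc(-c2cc(-c3ccccc3)cc(-c3ccsc3)n2)cc1` gives 1100 nM in a functional assay on HCT-15 cells (Homo sapiens) for cytotoxicity, read by ELISA, with a stated time of 2 days; on this read-out lower numbers stand for stronger inhibition and higher numbers for weaker inhibition.
Compound 2 `Oc1ccc(-c2cc(-c3ccccc3)cc(-c3ccco3)n2)cc1` gives 3500 nM in this assay.
Compound 3 `Oc1cccc(-c2cc(-c3ccccc3)nc(-c3ccsc3)c2)c1` gives 24600 nM in this assay.

Compounds 1 and 2 share a core and differ in one group: furan-2-yl in place of thiophen-3-yl on an aromatic carbon. This gives a 3.2-fold higher number from compound 1 to compound 2 (0.50 log units; beyond the scatter). Compound 3 has the same atoms as compound 1 joined differently; the difference between the two cores is not broken down here. Compound 3 stands highest of the three, with compound 2 nearest and compound 1 furthest.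

Compound 4 `Oc1cccc(-c2cc(-c3ccccc3)nc(-c3ccco3)c2)c1` is not yet measured. It differs from compound 3 as furan-2-yl in place of thiophen-3-yl on an aromatic carbon. This is the same kind of change as that from compound 1 to compound 2, not the same: around the place, in compound 3 and compound 4 the carbon is meta to a 3-hydroxyphenyl group, where in compound 1 and compound 2 it is meta to a 4-hydroxyphenyl group.

Within the data shown here, only one earlier instance of this change is known, on the other core, so the expectation for compound 4 rests on that single step. The step from compound 3 to compound 4 in this assay is expected to be of about the same size and direction as the one already seen on the other core: a 2.8-fold higher number from compound 3 to compound 4 (0.45 log units; beyond the scatter), set beside a 3.2-fold higher number from compound 1 to compound 2 (0.50 log units; beyond the scatter). Compound 4 is accordingly estimated at 70000 nM, with a range from 25000 nM to 200000 nM. Among the measured compounds shown here, compound 3 already gives 24600 nM, the highest number of the three, so the expected number for compound 4 lies above every value so far.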

Compound 4, half-maximal inhibitory concentration: 13900 nM
Compound 4: middle estimate off by 5.0-fold (0.70 log units), on the high side; the whole stated range lies above it.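

The exchange of thiophen-3-yl for furan-2-yl does not carry over unchanged from the core of compound 1 to the core of compound 3 in this assay. On the second core the result is a 1.8-fold lower number from compound 3 to compound 4 (0.25 log units; within the scatter), so the weakening seen on the first core does not recur, and the two steps differ: the same change on two cores in this assay, a 3.2-fold higher number (0.50 log units; beyond the scatter) from compound 1 to compound 2 and a 1.8-fold lower number (0.25 log units; within the scatter) from compound 3 to compound 4, 5.6-fold (0.75 log units) apart, beyond the scatter of two such steps

This shows that, for these two pairs, a step read on one core is a poor guide to the same change on the other, but it does not show which part of the difference between the cores matters, nor does it show that furan-2-yl is better than thiophen-3-yl on the core of compound 3, as that step lies within the scatter. Among these compounds, with only two pairs, it gives no rule for the wider series.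

The compounds shown leave open how other groups would behave at this place on either core, for instance an amine, a carboxylic acid or a pyridine ring in place of the thiophen-3-yl or furan-2-yl group. They also leave open whether the same dependence on the core would hold with a methoxy group in place of the hydroxy group on the hydroxyphenyl ring.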